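Swapping methyl for bromo in a weakly cytotoxic series

The compounds below may be only part of what the source reports. "The series", "measured", "known", "first", "only" and "open" are said of these compounds alone.

Three compounds were measured in a functional assay on SK-MEL-2 cells (Homo sapiens) for cytotoxicity; on this read-out lower numbers stand for stronger inhibition and higher numbers for weaker inhibition. Compound 2 `Cc1ccc(C2CN(S(=O)(=O)c3ccc(Cl)cc3)C(=O)N2)cc1` gives 123000 nM, and compound 1 `O=C1NC(c2ccc(Br)cc2)CN1S(=O)(=O)c1ccc(Cl)cc1` gives 111000 nM. The change between them, (bromo in place of methyl on an aromatic carbon), produced a 1.1-fold lower number from compound 2 to compound 1 (0.04 log units; within the scatter). Compound 3 `Cc1ccc(C2CNC(=O)N2S(=O)(=O)c2ccc3c(c2)CCC3)cc1` carries a different core; how its core differs from that of compound 2 is not broken down here. In this assay compound 3 gives 88600 nM, which lies within the scatter of the other two values. Compound 4 `O=C1NCC(c2ccc(Br)cc2)N1S(=O)(=O)c1ccc2c(c1)CCC2` has not yet been measured. It differs from compound 3 by the same change that turns compound 2 into compound 1, namely (bromo in place of methyl on an aromatic carbon). Because the earlier step of a 1.1-fold lower number from compound 2 to compound 1 (0.04 log units; within the scatter) stayed within the scatter, the expected step here is a 1.1-fold lower number from compound 3 to compound 4 (0.04 log units; within the scatter). Compound 4 is therefore expected to give 80000 nM, most likely between 40000 nM and 160000 nM.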

Compound 4, half-maximal inhibitory concentration: 119000 nM
Compound 4: the middle estimate sits 1.5-fold (0.17 log units) below what was measured, and the stated range covers the measured number.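

Putting bromo in place of methyl on the core of compound 3 gives a 1.3-fold higher number from compound 3 to compound 4 (0.13 log units; within the scatter) in this assay. The same change on the two cores gives steps that agree: the same change on two cores in this assay, a 1.1-fold lower number (0.04 log units; within the scatter) from compound 2 to compound 1 and a 1.3-fold higher number (0.13 log units; within the scatter) from compound 3 to compound 4, 1.5-fold (0.17 log units) apart, within the scatter of two such steps. So on both cores this swap leaves the number within the scatter, but that does not show the change carries over in any finer sense, since neither step is large enough to compare, and two cores are a small sample.

The compounds shown leave open whether a different group in this place, such as an amine or a carboxylic acid, would move the number beyond the scatter. They also leave open whether such a step would repeat from one core to the other.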